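A Fluoro Swap Carried From One Core to Another

The source may report more compounds than this note shows. Statements on the series, on what has been measured and on what is new or still open speak of the compounds shown alone.

Of the compounds shown here, three have so far been measured in an assay on isolated protein for inhibition of Ca2+/calmodulin-dependent protein kinase II (CaM kinase II) (Rattus norvegicus), tested at 30 uM; a higher number here means more inhibition at the concentration tested (going by the name of the read-out), a lower number less inhibition. Compound 1 `c1ccc(C[n+]2c[nH]c3ncncc32)cc1` gives 7% in this assay. Compound 2 `Fc1ccc(C[n+]2c[nH]c3ncncc32)cc1` gives 5% in this assay. The change from compound 1 to compound 2 is fluoro in place of hydrogen on an aromatic carbon, and the step was a number 2 percentage points lower from compound 1 to compound 2 (within the scatter). Compound 3 `Clc1ncnc2ncn(Cc3ccccc3)c12` gives 0% in this assay; its value lies within the scatter of the values of compound 1 and compound 2, so no order among the three can be read from these numbers. The difference between the core of compound 1 and the core of compound 3 is not broken down here.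

Compound 4 `Fc1ccc(Cn2cnc3ncnc(Cl)c32)cc1` has not yet been measured. It differs from compound 3 by fluoro in place of hydrogen on an aromatic carbon, the same kind of change as from compound 1 to compound 2. Because that earlier change gave a number 2 percentage points lower from compound 1 to compound 2 (within the scatter), the step now expected is a number 1 percentage points higher from compound 3 to compound 4 (within the scatter). This expectation rests also on compound 3, whose value of 0% leaves little room downward. Compound 4 is therefore estimated at about 1% in this assay, probably between -5% and 8%.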

Compound 4, a percentage reported as inhibition, at one concentration (the size of the read-out at that concentration, not a potency): 8%
Compound 4: the middle estimate sits 7 percentage points below what was measured; low and high end bracket the measured number.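

In this assay, fluoro in place of hydrogen on the aromatic carbon para to a large group gives a number 8 percentage points higher from compound 3 to compound 4 (within the scatter) and so leaves the read-out inside the usual scatter on this core as well. Set beside the earlier step, the change looks no different on the two cores: the same change on two cores in this assay, a number 2 percentage points lower (within the scatter) from compound 1 to compound 2 and a number 8 percentage points higher (within the scatter) from compound 3 to compound 4, 10 percentage points apart, within the scatter of two such steps. Among these compounds, this shows only that the swap produces no step that stands out from the scatter on either core; it does not show that fluoro acts the same way on both, as a step inside the scatter gives no reliable size to carry from one core to another.

Every compound shown has either hydrogen or fluoro at this place on the aromatic ring, so the effect of a different group there, such as an amine, a carboxylic acid or a longer chain, remains open. Also open, going by these compounds, is whether replacing the chloro group on the core of compound 3 with an amine would give a step beyond the scatter.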